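Aryl group swap on the shared core: cyano-fluoro analogue

The compounds below may be only part of what the source reports. "The series", "measured", "known", "first", "only" and "open" are said of these compounds alone.

Compound 3 `NS(=O)(=O)CC(=O)NCCSc1nonc1/C(=N/O)Nc1cccc(Br)c1` gives 30 nM in an assay for inhibition of Indoleamine 2,3-dioxygenase 1 (Homo sapiens), read by fluorescence, with a stated time of 1 h (on this read-out lower numbers stand for stronger inhibition and higher numbers for weaker inhibition), the lowest number of the three measured. Compound 1 `NS(=O)(=O)CC(=O)NCCSc1nonc1/C(=N/O)Nc1ccc(F)c(C(F)F)c1` gives 73 nM in this assay, and compound 2 `N#Cc1cccc(N/C(=N\O)c2nonc2SCCNC(=O)CS(N)(=O)=O)c1` gives 240 nM; the steps of a 2.4-fold lower number from compound 1 to compound 3 (0.39 log units; beyond the scatter) and an 8.0-fold lower number from compound 2 to compound 3 (0.90 log units; beyond the scatter) both run beyond the scatter.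

Compound 4 `N#Cc1cc(N/C(=N\O)c2nonc2SCCNC(=O)CS(N)(=O)=O)ccc1F` carries the change (3-cyano-4-fluorophenyl in place of 3-bromophenyl on an amine nitrogen). It is a 3-cyano-4-fluorophenyl in place of 3-bromophenyl on an amine nitrogen whose other neighbours are a carbon with a double bond to nitrogen. Within the data shown here, two measured steps bear on it. The step of an 8.0-fold lower number from compound 2 to compound 3 (0.90 log units; beyond the scatter) shows what bromo against cyano on this aromatic carbon does; compound 4 reverses that exchange while adding a fluorine. Among the measured compounds shown here, no measured pair isolates the added fluorine; only compound 1 carries one, and the step of a 3.3-fold higher number from compound 1 to compound 2 (0.52 log units; beyond the scatter) gives a rough sense that a fluorine-bearing aryl need not sit far from the 3-cyanophenyl analogue.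

A higher number is therefore expected for compound 4 in this assay, a step of a 5.0-fold higher number from compound 3 to compound 4 (0.70 log units; beyond the scatter) on the order of the cyano-for-bromo step, possibly tempered. The estimate for compound 4 is 150 nM, with a range from 50 nM to 450 nM.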

Compound 4, half-maximal inhibitory concentration: 150 nM
For compound 4 middle estimate and measured number coincide at the digits printed; measured number inside the range.
By their numbers in this assay, from the lowest: compound 3; then compound 1; then compounds 4 and 2 (each within the scatter of the next).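

In this assay, the step of a 5.0-fold higher number from compound 3 to compound 4 (0.70 log units; beyond the scatter) shows that 3-cyano-4-fluorophenyl on an amine nitrogen does not recover the level of 3-bromophenyl, which keeps the lowest number of the four compounds. Among these compounds, the step of a 1.6-fold lower number from compound 2 to compound 4 (0.20 log units; within the scatter) isolates fluoro in place of hydrogen on an aromatic carbon for the first time, and on the cyano-bearing aryl this exchange gives no difference that can be read above the scatter. Among the compounds shown here, with that fluoro present on both aryl groups, the step of a 2.1-fold higher number from compound 1 to compound 4 (0.31 log units; beyond the scatter) gives the first direct comparison of cyano with difluoromethyl on an aromatic carbon, and the modest gap favours difluoromethyl, with the lower number on compound 1.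

Nothing available here accounts for this ranking of the aryl groups. The compounds shown leave open whether fluoro in place of hydrogen would stay as silent on the 3-bromophenyl group, and where chloro, iodo or trifluoromethyl in place of bromo on the aromatic carbon would fall in this series.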